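Working notes: compound 3 to compound 4 in microsomal stability

The source may hold more compounds than are shown below. What is called first, only, known or untested is meant among the compounds shown, and "the series" means these compounds.

The series shares one core, carried by compound 1 `Cc1ccncc1N1CCN(C(=O)CCS(=O)(=O)c2cccc3ncsc23)CC1`, compound 2 `O=C(CCS(=O)(=O)c1cccc2ncsc12)N1CCN(c2ccc(Cl)cn2)CC1` and compound 3 `O=C(CCS(=O)(=O)c1cccc2ncsc12)N1CCN(c2ccc(C(F)(F)F)cn2)CC1`, which differ only in the aromatic group on the amine nitrogen in the ring. In an ADME assay on microsomes from liver (Rattus norvegicus) for metabolic stability, read by LC-MS, with a stated time of 15 min, tested at 1 uM (on this read-out lower numbers stand for a less stable compound and higher numbers for a more stable compound), compound 1 gives "not determined" (no result reported). In this assay compound 2 gives 31%. In this assay compound 3 gives 41%. Going by the values given here, the only step between measured compounds is a number 10 percentage points higher from compound 2 to compound 3 (within the scatter). Compound 3 therefore stands with compound 2 inside the scatter of a single repeat, and compound 1 contributes no number to compare against.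

Compound 4 `O=C(CCS(=O)(=O)c1cccc2ncsc12)N1CCN(c2ccncc2F)CC1` differs from compound 3 by 3-fluoropyridin-4-yl in place of 5-(trifluoromethyl)pyridin-2-yl on an amine nitrogen in a ring. Among the compounds with values here, the measured step of a number 10 percentage points higher from compound 2 to compound 3 (within the scatter) is the only one that bears on this change, and it exchanged one substituent on an otherwise unchanged aromatic group; the move to compound 4 replaces the whole aromatic group, so no measured step covers it directly. With that single step within the scatter, no shift beyond the scatter in this assay is expected in either direction, though the range is kept wide. The step of a number 6 percentage points lower from compound 3 to compound 4 (within the scatter) is expected to lie within the scatter. Compound 4 is estimated at 35%, with a range from 15% to 60%.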

Compound 4, percent of the compound remaining: 29%
For compound 4 the middle estimate is 6 percentage points above the measured one; the range from low to high includes it.
By their numbers in this assay, from the lowest: compounds 4, 2 and 3 (each within the scatter of the next, the first and the last beyond it).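

In this assay, going by these compounds alone, exchanging the whole aromatic group on the amine nitrogen in the ring gives a number 12 percentage points lower from compound 3 to compound 4 (beyond the scatter), the only step beyond the scatter, so a change at this position can shift the read-out, if only modestly. The same 3-fluoropyridin-4-yl group in place of 5-chloropyridin-2-yl gives a number 2 percentage points lower from compound 2 to compound 4 (within the scatter), so the shift appears only against the 5-(trifluoromethyl)pyridin-2-yl group and is not a general result of introducing 3-fluoropyridin-4-yl. Nothing measured in these notes offers an explanation for this difference between the two steps.

The move from compound 3 to compound 4 alters both the substituent and the point at which the pyridine is attached, and the compounds shown do not separate these two changes. Also open, from the compounds shown here alone, is how a plain phenyl group, or a pyridin-2-yl group carrying an amine or a carboxylic acid, would stand at this place in this assay.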